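From cyclopentyl to isobutyl on a triple-bonded carbon

The source may hold more compounds than are shown below. What is called first, only, known or untested is meant among the compounds shown, and "the series" means these compounds.

- Compound 1 `CN1CCN(CC#Cc2cc3ncnc(Nc4ccc(OCc5cccc(F)c5)c(Cl)c4)c3s2)CC1`: 11 uM
- Compound 2 `Fc1cccc(COc2ccc(Nc3ncnc4cc(C#CC5CCCC5)sc34)cc2Cl)c1`: > 31 uM (a limit)

In an ADME assay on HepG2 cells (Homo sapiens) for cytotoxicity (a lower number here means that less compound is tolerated, a higher number that more compound is tolerated), compound 2 stands at > 31 uM, which is a limit and not a number. Compound 3 `CC(C)CC#Cc1cc2ncnc(Nc3ccc(OCc4cccc(F)c4)c(Cl)c3)c2s1` keeps the shared core and carries isobutyl in place of cyclopentyl on a triple-bonded carbon. Both groups are carbon only, with no hydrogen-bond donors or acceptors and no net charge. Going by the values given here, the one measured step that bears on this is an at least 2.8-fold higher number from compound 1 to compound 2 (0.44 log units; beyond the scatter), where cyclopentyl took the place of (4-methylpiperazin-1-yl)methyl. That step removed a different group, so it offers only a loose guide, and no change beyond the scatter is expected in this assay. The expected change is a step that the limit leaves unreadable from compound 2 to compound 3. Compound 3 is expected at about 35 uM, with an estimated range of 18 uM to 70 uM.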

Compound 3, half-maximal toxic concentration: > 32 uM
Compound 3 gave a limit, no number; the forecaster's own chance of this, stated with the estimate: 55%; the middle value lies beyond the limit too.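

In this assay compound 3 gives > 32 uM, a limit of the assay and not a number. Isobutyl, which has no ring, moves the number the same way as cyclopentyl when set against the group carrying 4-methylpiperazin-1-yl, with an at least 2.9-fold higher number from compound 1 to compound 3 (0.46 log units; beyond the scatter). The ring of cyclopentyl is therefore not needed for this higher number at this place, and a second carbon-only group now shows the same direction.

On these data alone, the step between compound 2 and compound 3 cannot be read, as both stand at limits, so how these two groups rank and how far either lies past its limit stay open. Also open, as far as these compounds go, is whether a carboxylic acid or a primary amine on the triple-bonded carbon would fall towards compound 1 or stay with compound 2 and compound 3.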